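From Cyclopentyl to Propargyl: Estimating a Distribution Coefficient

The compounds below may be only part of what the source reports. "The series", "measured", "known", "first", "only" and "open" are said of these compounds alone.

In a physicochemical assay for lipophilicity (on this read-out lower numbers stand for lower lipophilicity and higher numbers for higher lipophilicity), compound 1 (`C#CCC(C)OC[n+]1ccn(C)c1/C=N/O`) reads -2.1 and compound 2 (`C#CCC(CCC)OC[n+]1ccn(C)c1/C=N/O`) reads -1.17 on the scale. Compound 3 (`Cn1cc[n+](COC(c2ccccc2)C2CCCC2)c1/C=N/O`) reads 0.38 as the highest of the three, and its gaps to the other two both lie beyond the scatter.

Compound 4 (`C#CCC(OC[n+]1ccn(C)c1/C=N/O)c1ccccc1`) has not yet been measured. It differs from compound 3 by one change (propargyl in place of cyclopentyl on a saturated chain carbon bound to an aromatic carbon and an oxygen on a saturated carbon) and carries the same propargyl as compound 1 and compound 2, whose values both lie under that of compound 3.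

Among the measured compounds shown here, one measured step bears on this change. It is a number 0.93 log units higher from compound 1 to compound 2 (beyond the scatter) when ethyl stands in place of hydrogen on a saturated chain carbon, so there a larger group went with a higher number. For the measured compounds named here, no measured step swaps cyclopentyl for propargyl directly, and the step at hand sits on a different compound pair, so it serves only as a rough guide. Here the entering group is the smaller one and has no ring, which points to a fall. The expected change is a number 1.28 log units lower from compound 3 to compound 4 (beyond the scatter) in this assay and this estimated fall is somewhat larger than the measured step and beyond the scatter. Compound 4 is estimated at -0.9 with an expected range from -1.4 to -0.4 on this scale.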

Compound 4, distribution coefficient: -1.05
The estimate for compound 4 lay 0.15 log units above the measured number; the measured number falls inside the stated range.
By their numbers in this assay, from the lowest: compound 1; then compounds 2 and 4 (each within the scatter of the next); then compound 3.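

In this assay, propargyl in place of cyclopentyl, on a saturated chain carbon bound to an aromatic carbon and an oxygen on a saturated carbon, gives a number 1.43 log units lower from compound 3 to compound 4 (beyond the scatter), the first direct measure of this swap. At the saturated chain carbon bound to an oxygen on a saturated carbon and a saturated chain carbon, phenyl in place of propyl gives a number 0.12 log units higher from compound 2 to compound 4 (within the scatter), so this read-out does not separate the two groups, whereas phenyl in place of methyl gives a number 1.05 log units higher from compound 1 to compound 4 (beyond the scatter). Nothing shown here explains why these steps differ in size.

It remains open whether the swap of cyclopentyl for propargyl would give a step of similar size if propyl or methyl stood in place of phenyl on the same carbon, since only one such pair is shown. On these data alone, it is also open what this assay would read with a longer chain such as hexyl, or with an amine, in place of propargyl.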